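The source may hold more compounds than are shown below. What is called first, only, known or untested is meant among the compounds shown, and "the series" means these compounds.

In a functional assay on HepG2 cells (Homo sapiens) for inhibition, read by MTT assay, with a stated time of 48 h (a lower number here means a stronger inhibitor, a higher number a weaker inhibitor), compound 1 `COc1cc(/C=N/Nc2nc(-c3ccc(Br)cc3)cs2)cc(Br)c1OC` gives 64600 nM and compound 2 `COc1cc(/C=N/Nc2nc(-c3ccccc3)cs2)cc(Br)c1OC` gives 68300 nM, so compound 2 sits level with compound 1 within the scatter. Compound 3 `COc1ccccc1-c1csc(N/N=C/c2cc(Br)c(OC)c(OC)c2)n1` differs from compound 2 by methoxy in place of hydrogen on an aromatic carbon, ortho to a large group, which gives phenyl to 2-methoxyphenyl. Going by the values given here, the only measured step, a 1.1-fold higher number from compound 1 to compound 2 (0.02 log units; within the scatter), also changes a substituent on this phenyl, and it stays within the scatter. From that single step, no change beyond the scatter is expected, in either direction. The expected result is a 1.1-fold lower number from compound 2 to compound 3 (0.06 log units; within the scatter). For compound 3 the estimate is 60000 nM, with an expected range of 25000 nM to 100000 nM.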

Compound 3, half-maximal inhibitory concentration: 82100 nM
Estimate against measurement, compound 3: 1.4-fold (0.14 log units) below; measured number inside the range.
By their numbers in this assay, from the lowest: compounds 1, 2 and 3 (each within the scatter of the next).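

Placing methoxy on the phenyl ring, ortho to a large group, gives a 1.2-fold higher number from compound 2 to compound 3 (0.08 log units; within the scatter) in this assay, so this first substitution at this position leaves the number within the scatter. Replacing 4-bromophenyl with 2-methoxyphenyl gives a 1.3-fold higher number from compound 1 to compound 3 (0.10 log units; within the scatter), so compound 1, compound 2 and compound 3 all remain level. No measurement here offers an explanation for this result. As far as these compounds go, whether an amine, a carboxylic acid or a longer alkoxy chain at this position would move the number beyond the scatter remains open.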